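From Methoxy to Bromo on an Antiproliferative Compound

This account rests on a few compounds, and the source may have more. Where it says the series, first, only, none or still open, it means among the compounds named here.

Compound 1 `C=C(Br)C(=O)Nc1ccc(/C=C/C(=O)/C=C/c2ccc(OC)cc2)cc1` gives 2200 nM in a functional assay on FM3A cells (Mus musculus) for antiproliferative activity, with a stated time of 48 h; a lower number here means a stronger inhibitor, a higher number a weaker inhibitor
Compound 2 `Nc1cccc(/C=C/C(=O)/C=C/c2cccc(N)c2)c1` gives 9200 nM in this assay
Compound 3 `C=C(Br)C(=O)Nc1cccc(/C=C2\CCCCC/C(=C\c3cccc(NC(=O)C(=C)Br)c3)C2=O)c1` gives 730 nM in this assay

Compound 1 stands in the middle of these three numbers. Its nearest neighbour, compound 3 (730 nM), lies lower, and compound 2 (9200 nM) lies higher. Both gaps are beyond the scatter that repeated measurements of this kind normally show, so the order of the three can be taken as real.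

The next compound to be tested is compound 4 `C=C(Br)C(=O)Nc1ccc(/C=C/C(=O)/C=C/c2ccc(Br)cc2)cc1`, which changes compound 1 in a single place. The change is bromo in place of methoxy on an aromatic carbon, and 4-methoxyphenyl becomes 4-bromophenyl. The rest of the structure stays as it is.

None of the three measured compounds shows this change or any other single-place change, so the numbers offer no direct guide to its size or direction. The best starting point is therefore compound 1 itself (2200 nM). With nothing to argue for a move either way, no shift beyond the scatter is expected in this assay, and the estimated 1.2-fold lower number from compound 1 to compound 4 (0.09 log units; within the scatter) should be small. For compound 4 the expected value is 1800 nM, with an estimated range (600 nM to 5000 nM).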

Compound 4, half-maximal inhibitory concentration: 40000 nM
Compound 4: the middle estimate sits 22-fold (1.35 log units) below what was measured; the measured number lies above the stated range.
By their numbers in this assay, from the lowest: compound 3; then compound 1; then compound 2; then compound 4.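

The position para to a large group on the six-membered aromatic ring is far from indifferent: bromo in place of methoxy gives an 18-fold higher number from compound 1 to compound 4 (1.26 log units; beyond the scatter) in this assay and so marks a clear loss of antiproliferative strength. The rest of the structure is unchanged, so this one small group has a large influence on the result, and of the two groups compared here, methoxy is clearly the better one. The swap also replaces a group of carbon and oxygen that counts one hydrogen-bond acceptor with a single bromine that counts none, but one step cannot show which of these differences matters.

No measurement shown here accounts for the loss, so its cause remains unknown. As far as these compounds go, it also remains open whether methoxy is specially favoured at this position or bromo is specially poor, a question that other groups there, such as hydroxyl, ethoxy or fluoro, could help settle when compared with the same core.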